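This account rests on a few compounds, and the source may have more. Where it says the series, first, only, none or still open, it means among the compounds named here.

Working notes on the series. In a functional assay on B16-F10 cells (Mus musculus) for antiproliferative activity, read by MTT assay, with a stated time of 48 h (a lower number here means a stronger inhibitor, a higher number a weaker inhibitor), compound 1 (`O=C(/C=C/c1ccc(O)c(O)c1)N1CCN(c2ccccc2Cl)CC1`) gives 1.82 ug/mL, compound 2 (`O=C(/C=C/c1ccc(O)c(O)c1)N1CCN(c2cccc(Cl)c2)CC1`) gives 1.71 ug/mL and compound 3 (`COc1ccccc1N1CCN(C(=O)/C=C/c2ccc(O)c(O)c2)CC1`) gives 1.23 ug/mL, so compound 3 stands within the scatter of both others. Compound 4 (`COc1cccc(N2CCN(C(=O)/C=C/c3ccc(O)c(O)c3)CC2)c1`) differs from compound 3 by one change: 3-methoxyphenyl in place of 2-methoxyphenyl on an amine nitrogen in a ring. Going by the values given here, the closest precedent is 3-chlorophenyl in place of 2-chlorophenyl, a 1.1-fold lower number from compound 1 to compound 2 (0.03 log units; within the scatter). The other two steps, a 1.5-fold lower number from compound 1 to compound 3 (0.17 log units; within the scatter) and a 1.4-fold lower number from compound 2 to compound 3 (0.14 log units; within the scatter), also stay within the scatter. No step beyond the scatter is therefore expected in this assay, and the data favour no direction. The expected step is a 1.1-fold higher number from compound 3 to compound 4 (0.06 log units; within the scatter). Compound 4 is estimated at 1.4 ug/mL, with an expected range of 0.8 ug/mL to 2.4 ug/mL.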

Compound 4, half-maximal inhibitory concentration: 1.46 ug/mL
Compound 4: the middle estimate sits 1.0-fold (0.02 log units) below what was measured; measured number inside the range.
By their numbers in this assay, from the lowest: compounds 3, 4, 2 and 1 (each within the scatter of the next).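

In this assay the position change now reads on methoxy as well as on chloro, and it again stays within the scatter (a 1.2-fold higher number from compound 3 to compound 4 (0.07 log units; within the scatter)). Compound 4 also stays within the scatter of both chloro compounds (a 1.2-fold lower number from compound 2 to compound 4 (0.07 log units; within the scatter); a 1.2-fold lower number from compound 1 to compound 4 (0.10 log units; within the scatter)). Methoxy in place of chloro can now be read on two cores, and the two readings agree: the same change on two cores in this assay, a 1.5-fold lower number (0.17 log units; within the scatter) from compound 1 to compound 3 and a 1.2-fold lower number (0.07 log units; within the scatter) from compound 2 to compound 4, 1.3-fold (0.10 log units) apart, within the scatter of two such steps.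

The compounds shown leave open whether a different group at this place, such as an amine or a carboxylic acid in place of methoxy or chloro, would give a step beyond the scatter.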